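This account rests on a few compounds, and the source may have more. Where it says the series, first, only, none or still open, it means among the compounds named here.

The three measured compounds share one core. Compound 1 `C(#Cc1[nH]cnc2ncnc1-2)c1ccccc1` gives 5.9 ug/mL in a functional assay on K562 cells (Homo sapiens) for inhibition, read by thymidine incorporation, with a stated time of 5 h; a higher number here means a weaker inhibitor, a lower number a stronger inhibitor. Compound 2 `C(#Cc1ncnc2c1ncn2Cc1ccccc1)c1ccccc1` gives 6 ug/mL in this assay, a value within the scatter of that of compound 1. Compound 3 `Clc1nc(C#Cc2ccccc2)c2ncn(Cc3ccccc3)c2n1` gives 0.8 ug/mL in this assay, the lowest of the three numbers, separated from compound 1 and from compound 2 by steps beyond the scatter. Going by the values given here, the one single-point step among the measured compounds is a 7.5-fold lower number from compound 2 to compound 3 (0.88 log units; beyond the scatter), brought about by chloro in place of hydrogen on an aromatic carbon.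

Compound 4 `C(#Cc1nc(-c2ccccc2)nc2c1ncn2Cc1ccccc1)c1ccccc1` differs from compound 3 in one place: phenyl in place of chloro on an aromatic carbon. Among the compounds with values here, only one measured step bears on this carbon, a 7.5-fold lower number from compound 2 to compound 3 (0.88 log units; beyond the scatter), which shows that putting a substituent at this carbon of the core can lower the number well beyond the scatter. Within the data shown here, no measured compound carries a phenyl at this carbon, so whether the larger group keeps, improves or loses the gain seen with chloro cannot be read from these data. Compound 4 is therefore expected to stay in the neighbourhood of compound 3, with some loss allowed for the change of group. The expected step is a 2.5-fold higher number from compound 3 to compound 4 (0.40 log units; beyond the scatter). For compound 4 the estimate in this assay is 2 ug/mL, with a range from 0.5 ug/mL to 8 ug/mL.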

Compound 4, half-maximal inhibitory concentration: 2.4 ug/mL
Estimate against measurement, compound 4: 1.2-fold (0.08 log units) below; low and high end bracket the measured number.
By their numbers in this assay, from the lowest: compound 3; then compound 4; then compounds 1 and 2 (each within the scatter of the next).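

At the aromatic carbon between two ring nitrogen atoms, replacing chloro with phenyl gives a 3.0-fold higher number from compound 3 to compound 4 (0.48 log units; beyond the scatter) in this assay, so the larger group, carrying a six-membered aromatic ring of carbon only, gives back part of what chloro gained. Yet phenyl still stands ahead of hydrogen at the same carbon, with a 2.5-fold lower number from compound 2 to compound 4 (0.40 log units; beyond the scatter), so the first measured gain at this position is not confined to chloro, and a group far larger than chloro can still lower the number beyond the scatter. The carbon now has three measured states, with chloro giving the lowest number, phenyl the next and hydrogen the highest, but nothing measured alongside these numbers accounts for that order.

From the compounds shown here alone, three states at one carbon do not make a trend, so it remains open whether an amine, a methoxy group or a longer alkyl chain at this carbon would fall nearer to chloro, nearer to phenyl or beyond either. The compounds shown also leave open whether chloro or phenyl at this carbon would lower the number in the same way on the core of compound 1.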